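The source may report more compounds than this note shows. Statements on the series, on what has been measured and on what is new or still open speak of the compounds shown alone.

Compound 1 `CC(C)Nc1nc(N)nc2c1ncn2/C=C1/CC1(CO)CO`: "not determined" (no result reported)
Compound 2 `CCCCCCSc1nc(N)nc2c1ncn2/C=C1/CC1(CO)CO`: > 20000 nM

These compounds were tested in an ADME assay on MOLT-3 cells (Homo sapiens) for cytotoxicity, with a stated time of 7 days; a lower number here means that less compound is tolerated, a higher number that more compound is tolerated. In this assay compound 2 gives > 20000 nM, which is a limit of the assay and not a number. Compound 1 has no result to compare, as its entry reads "not determined" (no result reported). Neither compound therefore offers a single number.

Compound 3 `CCCCCOc1nc(N)nc2c1ncn2/C=C1/CC1(CO)CO` has pentyloxy in place of hexylsulfanyl on an aromatic carbon, next to the ring nitrogen (pentyloxy in place of hexylsulfanyl on an aromatic carbon). Among the compounds with values here, no measured pair shows what a swap of this kind does in this assay. Within the data shown here, the only guide is compound 2 with its limit of > 20000 nM, so no step beyond the scatter is expected, in either direction. The estimated step is a number no higher from compound 2 to compound 3 (the limit leaves the size open). For compound 3 the expected value is 20000 nM, with an estimated range from 7000 nM to 40000 nM.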

Compound 3, half-maximal cytotoxic concentration: > 20000 nM
Compound 3 gave a limit, no number (the forecaster's own chance of this, stated with the estimate: 60%); the middle value lies on the limit itself.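

Compound 2 and compound 3 both end at a limit of the assay rather than a number, so no step between them can be read in this assay: the limit of > 20000 nM in this assay, at which 2 of the 3 values shown sit.

On these data alone, whether pentyloxy and hexylsulfanyl differ at all in how much compound the cells tolerate remains open.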